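Moving a Methyl on the Pyrrolidine Amide

The source may report more compounds than this note shows. Statements on the series, on what has been measured and on what is new or still open speak of the compounds shown alone.

Compound 1 `O=C(CCNc1nc2cc(Cl)ccc2o1)N1CCCC1`: 2.3 mL/min/g in an ADME assay on microsomes from liver (Homo sapiens) for metabolic stability, read by LC-MS, using NADPH, with a stated time of 45 min, tested at 0.5 uM; a lower number here means slower removal, a higher number faster removal of the compound
Compound 2 `CC1CCCN1C(=O)CCSc1nc2cc(Cl)ccc2o1`: 8.5 mL/min/g

Of the two compounds measured in this assay, compound 2 shows the higher number; the gap to compound 1 is beyond the usual scatter of such measurements, so compound 2 is the faster-cleared of the pair. Compound 3 `CC1CCN(C(=O)CCSc2nc3cc(Cl)ccc3o2)C1` has not yet been measured. It differs from compound 2 in a single place: 3-methylpyrrolidin-1-yl in place of 2-methylpyrrolidin-1-yl on a carbonyl carbon. Among the compounds with values here, no measured pair shows the effect of this change, so what follows rests only on compound 2 itself. The two compounds carry the same atoms joined differently, and nothing in the data suggests a large shift in either direction. Compound 3 is therefore expected to sit close to compound 2, with an estimated step of a 1.1-fold lower number from compound 2 to compound 3 (0.03 log units; within the scatter) in this assay that stays within the scatter. The estimate for compound 3 in this assay is 8 mL/min/g, with a range from 4 mL/min/g to 16 mL/min/g.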

Compound 3, intrinsic clearance in a liver preparation (reported as CLH), per the amount of preparation that the assay uses: 10.1 mL/min/g
Beside the measured number, compound 3's estimate is 1.3-fold (0.10 log units) below it, within the range that was stated.
By their numbers in this assay, from the lowest: compound 1; then compounds 2 and 3 (each within the scatter of the next).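

In this assay, 3-methylpyrrolidin-1-yl in place of 2-methylpyrrolidin-1-yl on the carbonyl carbon gives a 1.2-fold higher number from compound 2 to compound 3 (0.07 log units; within the scatter). Within the data shown here, this is the first comparison in the set that isolates a single place, and it shows that, for this pair, the two methylpyrrolidine amides cannot be told apart in this read-out. The data shown offer no measurement that bears on why the two compounds match.

Still open, on these data alone, is whether the methyl group itself matters at all, as the pair says nothing about an unsubstituted pyrrolidin-1-yl on the shared core of compound 2 and compound 3. Also open, as far as these compounds go, is how a larger amine on the same carbonyl carbon, such as piperidin-1-yl or morpholin-4-yl, would fare in this assay.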